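Pyridine in Place of Cyanophenyl: Solubility Expectation

A few compounds are considered here, and "the series" means these few. Any claim that something is new, unique, unknown or untested is made for them only; others in the source may bear on it.

Compound 2 `CC(=O)NC[C@H]1CN(c2ccc(OC[C@@H](O)CNc3ccc(C#N)cc3)c(F)c2)C(=O)O1` gives 47000 nM in a physicochemical assay for solubility, read by HPLC (on this read-out lower numbers stand for lower solubility and higher numbers for higher solubility), the lowest of the three numbers measured, though its gap to compound 3 is within the scatter. Compound 1 `CC(=O)NC[C@H]1CN(c2ccc(OC[C@@H](O)CNc3ccccc3)c(F)c2)C(=O)O1` gives 124000 nM and compound 3 `CC(=O)NC[C@H]1CN(c2ccc(OC[C@H](O)CNc3ccc(C#N)cc3)c(F)c2)C(=O)O1` gives 69000 nM. The step of a 2.6-fold lower number from compound 1 to compound 2 (0.42 log units; beyond the scatter) is modest yet beyond the scatter, while the step of a 1.5-fold higher number from compound 2 to compound 3 (0.17 log units; within the scatter) is not; the fact that compounds 2 and 3 differ only in the configuration as drawn underlies that second pair. Compound 4 `CC(=O)NC[C@H]1CN(c2ccc(OC[C@@H](O)CNc3ccncc3)c(F)c2)C(=O)O1` differs from compound 2 by pyridin-4-yl in place of 4-cyanophenyl on an amine nitrogen. Going by the values given here, neither measured step covers this change; the only guidance is the step of a 2.6-fold lower number from compound 1 to compound 2 (0.42 log units; beyond the scatter), in that compound 4 also carries no cyano group. A modest rise is therefore expected, a 1.9-fold higher number from compound 2 to compound 4 (0.28 log units; within the scatter), with little confidence beyond the scatter. For compound 4 the estimate is 90000 nM, ranging from 35000 nM to 250000 nM.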

Compound 4, solubility: 17700000 nM
The estimate for compound 4 lay 200-fold (2.29 log units) below the measured number; the whole stated range lies below it.
By their numbers in this assay, from the lowest: compounds 2, 3 and 1 (each within the scatter of the next, the first and the last beyond it); then compound 4.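

Going by these compounds alone, on this amine nitrogen, the choice of aromatic ring moves the number in this assay much further than the earlier compounds showed, with a 380-fold higher number from compound 2 to compound 4 (2.58 log units; beyond the scatter). Removing the nitrile does not account for this, since compound 1 has none either, and still there is a 140-fold higher number from compound 1 to compound 4 (2.15 log units; beyond the scatter). The large change therefore goes with the pyridin-4-yl ring itself.

Nothing shown here explains the size of this rise. Going by these compounds, it also remains open whether the rise is particular to pyridin-4-yl, or whether pyridin-3-yl on the same amine nitrogen would give a similar number.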